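Extending the chain on compound 2 with an amide

The source may hold more compounds than are shown below. What is called first, only, known or untested is meant among the compounds shown, and "the series" means these compounds.

Compound 2 `C=CCn1nc(-c2cccnc2)c2ccccc2c1=O` stands second highest of the three compounds measured in an assay on isolated protein (Oryctolagus cuniculus) with Thromboxane-A synthase (Homo sapiens) as the target, tested at 1 uM (a higher number here means more inhibition at the concentration tested (going by the name of the read-out), a lower number less inhibition), where compound 2 gives 70%. Compound 1 `CCCn1nc(-c2cccnc2)c2ccccc2c1=O` gives 86% and compound 3 `NCCn1nc(-c2cccnc2)c2ccccc2c1=O` gives 29%; the step of a number 16 percentage points lower from compound 1 to compound 2 (beyond the scatter) is modest, while a number 41 percentage points lower from compound 2 to compound 3 (beyond the scatter) and a number 57 percentage points lower from compound 1 to compound 3 (beyond the scatter) are large. Compound 4 `CC(C)NC(=O)CCCn1nc(-c2cccnc2)c2ccccc2c1=O` differs from compound 2 by 2-(isopropylcarbamoyl)ethyl in place of vinyl on a saturated chain carbon bound to an aromatic nitrogen. The step that bears most directly on this change is a number 41 percentage points lower from compound 2 to compound 3 (beyond the scatter), where aminomethyl in place of vinyl cut inhibition sharply. The entering group again brings a hydrogen-bond donor and acceptor, though on a longer chain, so a fall is expected, but one less steep than that to compound 3. Compound 4 is therefore estimated at 50%, within 25% to 75%, an expected step of a number 20 percentage points lower from compound 2 to compound 4 (beyond the scatter).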

Compound 4, a percentage reported as inhibition, at one concentration (the size of the read-out at that concentration, not a potency): 89%
Compound 4: the middle estimate sits 39 percentage points below what was measured, and the stated range ends below it.
By their numbers in this assay, from the lowest: compound 3; then compound 2; then compounds 1 and 4 (each within the scatter of the next).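

Among the compounds shown here, this position accepts a far larger group than the earlier compounds showed: 2-(isopropylcarbamoyl)ethyl in place of vinyl gives a number 19 percentage points higher from compound 2 to compound 4 (beyond the scatter) in this assay. A chain carrying a hydrogen-bond donor and acceptor therefore need not lower the number, as (isopropylcarbamoyl)methyl in place of amino gives a number 60 percentage points higher from compound 3 to compound 4 (beyond the scatter). Isopropylcarbamoyl in place of hydrogen on the chain gives a number 3 percentage points higher from compound 1 to compound 4 (within the scatter), so compound 1 and compound 4 cannot be told apart.

From the compounds shown here alone, whether a carboxylic acid or a longer chain ending in the same amide would hold this level stays open. Nothing available explains why the amide chain and the amino chain differ so much.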